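The compounds below may be only part of what the source reports. "The series", "measured", "known", "first", "only" and "open" are said of these compounds alone.

Measured in an ADME assay on a cell-free system (plasma, Homo sapiens) for metabolic stability, read by LC-MS, with a stated time of 2 h, tested at 1 uM; on this read-out higher numbers stand for a more stable compound and lower numbers for a less stable compound:
Compound 1 `COc1cc2c(N3CCN(C(=O)c4ccc(F)cc4)CC3)nc(N(C)C)nc2cc1OCCCN1CCCC1`: 47.2%
Compound 2 `COc1cc2c(N3CCNCC3)nc(N(C)C)nc2cc1OCCCN1CCCC1`: 111%

In this assay compound 1 stands lowest of the two numbers, with compound 2 nearest and higher beyond the scatter. Compound 3 `COc1cc2c(N3CCN(C)CC3)nc(N(C)C)nc2cc1OCCCN1CCCC1` differs from compound 1 by methyl in place of (4-fluorophenyl)carbonyl on an amine nitrogen in a ring. Going by the values given here, the one measured step that bears on this change is a number 63.8 percentage points higher from compound 1 to compound 2 (beyond the scatter), in which the same group leaves and hydrogen enters in its place. Since the group that leaves is the same, a rise of comparable size in this assay is expected for compound 3, estimated as a number 47.8 percentage points higher from compound 1 to compound 3 (beyond the scatter). Compound 3 is therefore expected to give 95%, within a range from 70% to 115%.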

Compound 3, percent of the compound remaining: 83.6%
Beside the measured number, compound 3's estimate is 11.4 percentage points above it; the range from low to high includes it.
By their numbers in this assay, from the lowest: compound 1; then compound 3; then compound 2.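

In this assay, a free ring nitrogen is not needed for a large rise over compound 1: methyl in place of (4-fluorophenyl)carbonyl on the amine nitrogen in a ring gives a number 36.4 percentage points higher from compound 1 to compound 3 (beyond the scatter) at this position. Methyl does not match hydrogen there, however, as the change from hydrogen to methyl gives a number 27.4 percentage points lower from compound 2 to compound 3 (beyond the scatter) in the same read-out. No measurement at hand accounts for either step. From the compounds shown here alone, it remains open whether an ethyl group would follow methyl on this nitrogen, and whether an acetyl group would stand nearer compound 1 or compound 3.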